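Swapping the Side Chain on the Imidazole Nitrogen

This account rests on a few compounds, and the source may have more. Where it says the series, first, only, none or still open, it means among the compounds named here.

Compound 1: `COC(=O)c1c(F)cccc1-c1ccc(CCc2ncc(CC(C)(C)C)n2CCOc2cccc(O)c2)cc1` gives 25 nM in an assay on cells for agonist activity at Bombesin receptor subtype-3 (Mus musculus), read by HTRF and inositol phosphate accumulation, with a stated time of 1 h; a lower number here means that less compound is needed, a higher number that more compound is needed for the effect.
Compound 2: `CC(C)(C)Cc1cnc(CCc2ccc(-c3cccc(F)c3C(=O)O)cc2)n1Cc1ccc(C(=O)O)cc1` gives 13 nM in this assay.

Compound 2 holds the lowest of the two numbers shown, and compound 1 sits within the scatter of it, so the two values cannot be told apart. Compound 3, `CC(C)(C)Cc1cnc(CCc2ccc(-c3cccc(F)c3C(=O)O)cc2)n1CCOc1cccc(O)c1`, has not yet been measured in this assay. It differs from compound 2 in one place: (3-hydroxyphenoxy)methyl in place of 4-carboxyphenyl on a saturated chain carbon bound to an aromatic nitrogen. The group that enters is the same one carried by compound 1, so compound 3 combines the side chain of compound 1 with the free carboxylic acid of compound 2. For the measured compounds named here, both measured values lie close together, and no step between them is established, so the expected step from compound 2 to compound 3 is a 1.3-fold higher number from compound 2 to compound 3 (0.12 log units; within the scatter), none beyond the scatter. The estimated value for compound 3 is 17 nM, with a range from 6 nM to 60 nM.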

Compound 3, half-maximal effective concentration: 0.8 nM
Beside the measured number, compound 3's estimate is 21-fold (1.33 log units) above it; the whole stated range lies above it.
By their numbers in this assay, from the lowest: compound 3; then compounds 2 and 1 (each within the scatter of the next).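

At the position on a saturated chain carbon bound to an aromatic nitrogen, 2-(3-hydroxyphenoxy)ethyl in place of 4-carboxybenzyl gives a 16-fold lower number from compound 2 to compound 3 (1.21 log units; beyond the scatter) in this assay although both groups hold 9 heavy atoms, so the result depends strongly on which group sits there, not on the atom count. Compound 1 and compound 2 differ in two places, and their close values gave no sign of this. The change at the other end of the molecule is also large: hydrogen in place of methyl on an oxygen next to a carbonyl group gives a 31-fold lower number from compound 1 to compound 3 (1.49 log units; beyond the scatter) with the side chain unchanged.

No measurement shown explains why either step is so large and it remains open how an amine or a longer chain would fare at this position.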